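This account rests on a few compounds, and the source may have more. Where it says the series, first, only, none or still open, it means among the compounds named here.

In a toxicity assay on WI-38 cells (Homo sapiens) for cytotoxicity, read by MTT assay, with a stated time of 48 h (on this read-out higher numbers stand for weaker inhibition and lower numbers for stronger inhibition), the measured compounds are:
Compound 1 `Cn1cccc1C(=O)/C=C/c1ccc2c(c1)B(O)OC2` gives > 100000 nM, which is a limit of the assay, not a number.
Compound 2 `O=C(/C=C/c1ccc2c(c1)B(O)OC2)c1ccc(F)cc1` gives 7600 nM.
Compound 3 `O=C(/C=C/c1ccc2c(c1)B(O)OC2)c1ccccc1F` gives 23600 nM.

Compound 3 therefore holds the highest of the two numbers in this assay; compound 2 is nearest, with the step of a 3.1-fold higher number from compound 2 to compound 3 (0.49 log units; beyond the scatter). Compound 4 `COc1ccccc1C(=O)/C=C/c1ccc2c(c1)B(O)OC2` differs from compound 3 by methoxy in place of fluoro on an aromatic carbon. Going by the values given here, none of the measured steps swaps one substituent for another on the same ring: the steps of an at least 13-fold lower number from compound 1 to compound 2 (1.11 log units; beyond the scatter) and an at least 4.2-fold lower number from compound 1 to compound 3 (0.62 log units; beyond the scatter) replace the whole group on the carbonyl carbon, and a 3.1-fold higher number from compound 2 to compound 3 (0.49 log units; beyond the scatter) only changes where the fluoro sits. The fluoro-to-methoxy swap is thus untested, so only a small change in this assay is expected, in either direction. Compound 4 is estimated at 22000 nM, between 6000 nM and 80000 nM. This expectation amounts to the step of a 1.1-fold lower number from compound 3 to compound 4 (0.03 log units; within the scatter).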

Compound 4, half-maximal inhibitory concentration: 21700 nM
For compound 4 the middle estimate is 1.0-fold (0.01 log units) above the measured one; low and high end bracket the measured number.
By their numbers in this assay, from the lowest: compound 2; then compounds 4 and 3 (each within the scatter of the next). At a limit, above all of these: compound 1.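

In this assay, methoxy in place of fluoro on an aromatic carbon, ortho to a large group, gives a 1.1-fold lower number from compound 3 to compound 4 (0.04 log units; within the scatter). Going by these compounds alone, this is the first swap of one substituent for another at this position, and it stays within the scatter, whereas moving the fluoro gave a 3.1-fold higher number from compound 2 to compound 3 (0.49 log units; beyond the scatter). Nothing measured here explains this result. From the compounds shown here alone, it remains open whether an amine, a carboxylic acid or a longer chain at this position would also stay within the scatter of compound 3. Also open, going by these compounds, is how methoxy would compare with fluoro at the position the fluoro holds in compound 2.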